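The source may hold more compounds than are shown below. What is called first, only, known or untested is meant among the compounds shown, and "the series" means these compounds.

Measured so far in a functional assay on MDA-MB-231 cells (Homo sapiens) for cytotoxicity, read by sulforhodamine B assay, with a stated time of 72 h; a higher number here means a weaker inhibitor of growth, a lower number a stronger inhibitor of growth:
Compound 1, `CC(=O)N1c2ccccc2CCC1C(=O)Nc1ccccc1O`, gives 89600 nM.
Compound 2, `CCC(=O)N1c2ccccc2CCC1C(=O)Nc1ccccc1C(F)(F)F`, gives > 80000 nM, which is a limit of the assay and not a number.
Compound 3, `CCC(=O)N1c2ccccc2CCC1C(=O)Nc1cc(C(F)(F)F)cc(C(F)(F)F)c1`, gives 7280 nM.

Compound 2 therefore stands at the limit of > 80000 nM in this assay, at which 1 of the 3 values shown sits, so only a bound on its strength is known, not a figure. Compound 4, `O=C(Nc1ccccc1C(F)(F)F)C1CCc2ccccc2N1C(=O)c1ccccc1Cl`, differs from compound 2 by 2-chlorophenyl in place of ethyl on a carbonyl carbon. Going by the values given here, no pair of measured compounds tests a change at this carbonyl, so the direction of the step is open. A modest gain in growth inhibition is expected, a step of an at least 2.0-fold lower number from compound 2 to compound 4 (0.30 log units; that floor lies within the scatter) from the bound of compound 2, with wide uncertainty. Compound 4 is estimated at 40000 nM, within a range from 10000 nM to 120000 nM.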

Compound 4, concentration for 50% growth inhibition: 2530 nM
For compound 4 the middle estimate is 16-fold (1.20 log units) above the measured one, outside the stated range (below it).
By their numbers in this assay, from the lowest: compound 4; then compound 3; then compound 1.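

Going by these compounds alone, no earlier pair tested this carbonyl carbon, and here the group on it proves to matter in this assay: 2-chlorophenyl in place of ethyl gives an at least 31-fold lower number from compound 2 to compound 4 (1.49 log units; beyond the scatter) with the rest of the molecule unchanged. Compound 2 sits at a limit of the assay, so this size is only a floor: the limit of > 80000 nM in this assay, at which 1 of the 4 values shown sits. The compounds shown cannot separate the part played by the ring from that of the chlorine, as a plain phenyl would. As far as these compounds go, whether a longer chain such as butanoyl or a ring bearing an amine would give a similar gain also remains open.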